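Aryl substituent effects in a thiosemicarbazone series: compound 4

The source may report more compounds than this note shows. Statements on the series, on what has been measured and on what is new or still open speak of the compounds shown alone.

Measured compounds:
compound 1, `CC1=CC[C@@H]([C@@](C)(O)CCCC(C)(C)NC(=S)N/N=C\c2ccccc2)CC1`, 6970 nM
compound 2, `CC1=CC[C@@H]([C@@](C)(O)CCCC(C)(C)NC(=S)N/N=C\c2cccc([N+](=O)[O-])c2)CC1`, 8510 nM
compound 3, `CC1=CC[C@@H]([C@@](C)(O)CCCC(C)(C)NC(=S)N/N=C\c2ccc([N+](=O)[O-])cc2)CC1`, 13400 nM

In a functional assay on OVCAR-3 cells (Homo sapiens) for cytotoxicity, read by sulforhodamine B assay (on this read-out lower numbers stand for stronger inhibition of growth and higher numbers for weaker inhibition of growth), compound 1 gives the lowest of the three numbers, but both its neighbours sit within the scatter: a 1.2-fold higher number from compound 1 to compound 2 (0.09 log units; within the scatter) and a 1.9-fold higher number from compound 1 to compound 3 (0.28 log units; within the scatter). Between the two nitro isomers the gap is also within the scatter, a 1.6-fold higher number from compound 2 to compound 3 (0.20 log units; within the scatter). So far the unsubstituted phenyl and either nitrophenyl behave alike in this assay.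

Compound 4, `CC1=CC[C@@H]([C@@](C)(O)CCCC(C)(C)NC(=S)N/N=C\c2ccc(Cl)cc2)CC1`, is not yet measured. Its difference from compound 1 is chloro in place of hydrogen on an aromatic carbon. The change most closely related is that from compound 1 to compound 3, where a nitro group enters at an aromatic carbon and the number moved only within the scatter; the change to compound 2 likewise stayed within the scatter. Nothing measured here separates a chloro from a nitro substituent, so the expectation rests on these two steps alone.

On that basis, for compound 4 no step beyond the scatter is expected in this assay; a slight rise in the number in line with the nitro analogues, a 1.2-fold higher number from compound 1 to compound 4 (0.09 log units; within the scatter), is the estimate. Compound 4 is therefore estimated at 8500 nM, with a range of 3500 nM to 20000 nM.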

Compound 4, concentration for 50% growth inhibition: 6660 nM
Compound 4: middle estimate off by 1.3-fold (0.11 log units), on the high side; the range from low to high includes it.
By their numbers in this assay, from the lowest: compounds 4, 1, 2 and 3 (each within the scatter of the next).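

In this assay, chloro in place of hydrogen on the aromatic carbon para to a large group gives a 1.0-fold lower number from compound 1 to compound 4 (0.02 log units; within the scatter) and so adds a substituent other than nitro to the series without a step beyond the scatter. Exchanging one substituent for the other at this position gives a 2.0-fold lower number from compound 3 to compound 4 (0.30 log units; within the scatter) as chloro replaces nitro, and the comparison with the other nitro isomer gives a 1.3-fold lower number from compound 2 to compound 4 (0.11 log units; within the scatter), so every step among the four aryl variants now lies within the scatter, and neither the presence of a substituent nor its identity separates them in this series. No accompanying data bear on these steps, so the series gives no account of this flat response.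

From the compounds shown here alone, whether the flat response extends to other kinds of substituent stays open, such as an amine, a carboxylic acid or a methoxy group on the phenyl ring. Also open, going by these compounds, is whether a change away from the aryl group, such as a longer chain in place of the one on the shared core, would give a step beyond the scatter in this assay.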